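Taking one methyl off a growth-inhibiting compound

A few compounds are considered here, and "the series" means these few. Any claim that something is new, unique, unknown or untested is made for them only; others in the source may bear on it.

Compound 1 `CN(C)C(=O)c1cc2cnc(Nc3ccc(NC(=O)C4(C(=O)Nc5ccc(Cl)c(C(F)(F)F)c5)CC4)cc3)nc2n1C1CCCC1` and compound 2 `Cc1ccc(NC(=O)C2(C(=O)Nc3ccc(Nc4ncc5cc(C(=O)N(C)C)n(C6CCCC6)c5n4)cc3)CC2)cc1` share one core and differ only in the aromatic group on an amide-type nitrogen. In a functional assay on NCI-H1299 cells (Homo sapiens) for inhibition, read by CCK-8 assay, with a stated time of 72 h, tested at 10 uM (on this read-out higher numbers stand for more inhibition of growth at the one concentration tested and lower numbers for less inhibition of growth), compound 1 gives 90.4% and compound 2 gives 84.5%. These two numbers lie within the usual scatter of each other, so compound 2 stands level with compound 1.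

The next compound, compound 3 `CN(C)C(=O)c1cc2cnc(Nc3ccc(NC(=O)C4(C(=O)Nc5ccccc5)CC4)cc3)nc2n1C1CCCC1`, changes that same group: hydrogen in place of methyl on an aromatic carbon. This is hydrogen in place of methyl on an aromatic carbon, turning 4-methylphenyl to phenyl. Among the measured compounds shown here, only one measured step bears on this change: a number 5.9 percentage points lower from compound 1 to compound 2 (within the scatter), with 4-methylphenyl in place of 4-chloro-3-(trifluoromethyl)phenyl. That exchange was heavier than the loss of a single methyl, and it stayed within the scatter. No shift beyond the scatter is therefore expected in this assay. The expected step is a number 2.5 percentage points lower from compound 2 to compound 3 (within the scatter). For the measured compounds named here, no measured compound yet carries a plain phenyl in this place, so the expected range stays wide. For compound 3 the estimate is 82%, with an expected range from 68% to 93%.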

Compound 3, percent growth inhibition at one concentration: 90.5%
Beside the measured number, compound 3's estimate is 8.5 percentage points below it; the measured number falls inside the stated range.
By their numbers in this assay, from the lowest: compounds 2, 1 and 3 (each within the scatter of the next).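

Taking the methyl off the aromatic carbon para to a large group, the change from 4-methylphenyl to phenyl, gives a number 6 percentage points higher from compound 2 to compound 3 (within the scatter) in this assay and so leaves growth inhibition level. The plain phenyl also stands level with the much larger group of compound 1, with a number 0.1 percentage points higher from compound 1 to compound 3 (within the scatter) on the same read-out, which means that among these three compounds neither the methyl nor the chlorine and trifluoromethyl pair is needed to keep the number where it is. Nothing measured here offers a reason for this flat result, and these numbers alone give no explanation of it.

Still open, as far as these compounds go, is whether a different kind of group on this ring, such as an amine, a carboxylic acid or a longer chain like a butyl group, would move the number beyond the usual scatter. Among the compounds shown here, each compound also has only one reading at a single concentration, so these numbers cannot tell whether compound 1, compound 2 and compound 3 would still stand level at lower concentrations.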